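One Change, Tried on Two Related Cores

The compounds below may be only part of what the source reports. "The series", "measured", "known", "first", "only" and "open" are said of these compounds alone.

Compound 2 `COc1ccccc1N1CCN(C(=O)CCN2C(=O)CSc3ccccc32)CC1` and compound 1 `O=C(CCN1C(=O)CSc2ccccc21)N1CCN(c2ccc(C(F)(F)F)cc2)CC1` differ in one place, (4-(trifluoromethyl)phenyl in place of 2-methoxyphenyl on an amine nitrogen in a ring). In a functional assay (MiaPaCa cells, Homo sapiens) for inhibition, read by sulforhodamine B assay, with a stated time of 48 h (a lower number here means a stronger inhibitor of growth, a higher number a weaker inhibitor of growth), compound 2 gives 34900 nM. In this assay compound 1 gives a limit rather than a number, > 100000 nM, as its value sits at the limit of > 100000 nM in this assay, at which 1 of the 3 values shown sits. The step of an at least 2.8-fold higher number from compound 2 to compound 1 (0.45 log units; beyond the scatter) thus points to weaker growth inhibition after this change. Compound 3 `COc1ccccc1N1CCN(CCCNC(=O)CCN2C(=O)CSc3ccccc32)CC1` carries the same 2-methoxyphenyl on a core that differs from the core of compound 2; how the two cores differ is not broken down here. In this assay compound 3 gives 59200 nM, and its value and that of compound 2 lie within the scatter of each other. Compound 4 `O=C(CCN1C(=O)CSc2ccccc21)NCCCN1CCN(c2ccc(C(F)(F)F)cc2)CC1` has not yet been measured; it differs from compound 3 by 4-(trifluoromethyl)phenyl in place of 2-methoxyphenyl on an amine nitrogen in a ring, the same change at the same place as between compound 2 and compound 1. Because that earlier change gave an at least 2.8-fold higher number from compound 2 to compound 1 (0.45 log units; beyond the scatter), a step of at least similar size is expected here, a 2.7-fold higher number from compound 3 to compound 4 (0.43 log units; beyond the scatter). Compound 4 is estimated at 160000 nM, between 60000 nM and 400000 nM, so a limit rather than a number is the likely report.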

Compound 4, concentration for 50% growth inhibition: > 100000 nM
Compound 4 was reported as a limit; the forecaster's own chance of this, stated with the estimate: 70%; the middle value lies beyond the limit too.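

In this assay compound 4 gives > 100000 nM, which is a limit of the assay and not a number. The step on this core reads an at least 1.6-fold higher number from compound 3 to compound 4 (0.22 log units; that floor lies within the scatter), so this floor alone does not establish that the change weakens growth inhibition here, although the true value could lie further from that of compound 3. Compound 1 and compound 4, the two compounds carrying 4-(trifluoromethyl)phenyl, are both reported as limits, so the result is compatible with the change carrying over from one core to the other but does not show that its size is the same: the same change on two cores in this assay, an at least 2.8-fold higher number (0.45 log units; beyond the scatter) from compound 2 to compound 1 and an at least 1.6-fold higher number (0.22 log units; that floor lies within the scatter) from compound 3 to compound 4; the limit leaves it open whether they differ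

From the compounds shown here alone, the true size of each step remains open, since neither compound 1 nor compound 4 has a number that can be set against its partner. Also open, going by these compounds, is how the two cores would respond to a plain phenyl group in the same place, or whether the pattern would hold on a core with a longer chain.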